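Compound 3: pyridazin-3-yl in place of pyrazin-2-yl

The compounds below may be only part of what the source reports. "The series", "measured", "known", "first", "only" and "open" are said of these compounds alone.

Compound 1 `C/C(=N\Nc1nc2ccccc2o1)c1cnc(C)cn1`: 290 nM
Compound 2 `C/C(=N\Nc1nc2ccccc2o1)c1cnccn1`: 340 nM

In a functional assay on HT-29 cells (Homo sapiens) for antiproliferative activity, read by sulforhodamine B assay (on this read-out lower numbers stand for stronger inhibition and higher numbers for weaker inhibition), compound 2 gives 340 nM, and compound 1 gives 290 nM. For the measured compounds named here, these two values lie within the scatter of each other, so compound 2 does not stand apart from the only other measured compound.

The next compound is compound 3 `C/C(=N\Nc1nc2ccccc2o1)c1cccnn1`, and its change from compound 2 is pyridazin-3-yl in place of pyrazin-2-yl on a carbon with a double bond to nitrogen.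

Going by the values given here, only one measured step is available: a 1.2-fold higher number from compound 1 to compound 2 (0.07 log units; within the scatter). That step is hydrogen in place of methyl on an aromatic carbon, so it bears on the new change only indirectly. Among the compounds with values here, no measured pair exchanges pyrazin-2-yl for pyridazin-3-yl, and the data favour no direction.

The estimated step is a 1.2-fold higher number from compound 2 to compound 3 (0.07 log units; within the scatter), so no change beyond the scatter is expected in this assay. For compound 3 the expected value is 400 nM, with an estimated range of 140 nM to 1200 nM.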

Compound 3, half-maximal inhibitory concentration: 2640 nM
Compound 3: middle estimate off by 6.6-fold (0.82 log units), on the low side; the whole stated range lies below it.
By their numbers in this assay, from the lowest: compounds 1 and 2 (each within the scatter of the next); then compound 3.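

In this assay, the group on the carbon with a double bond to nitrogen turns out to be sensitive to how its ring atoms are joined: pyridazin-3-yl in place of pyrazin-2-yl gives a 7.8-fold higher number from compound 2 to compound 3 (0.89 log units; beyond the scatter), whereas the earlier change, hydrogen in place of methyl on an aromatic carbon, gave only a 1.2-fold higher number from compound 1 to compound 2 (0.07 log units; within the scatter). The two groups match in heavy atoms and in counted hydrogen-bond donors and acceptors, so a step beyond the scatter appears here with no difference in any of these counts. Nothing available explains this step.

On these data alone, it remains open whether the higher number is specific to pyridazin-3-yl or would also appear with pyridin-2-yl or phenyl at this place. Also open, as far as these compounds go, is whether a methyl group on the pyridazin-3-yl ring would shift the number.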